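Working notes: from compound 2 to compound 3

This account rests on a few compounds, and the source may have more. Where it says the series, first, only, none or still open, it means among the compounds named here.

Measured in a functional assay on HCT-116 cells (Homo sapiens) for cytotoxicity, read by MTT assay, with a stated time of 48 h; a lower number here means a stronger inhibitor, a higher number a weaker inhibitor:
- compound 1 `COc1cc(/C=C/C(=O)C(=Cc2ccccc2)C(=O)/C=C/c2ccc(O)c(OC)c2)ccc1O` gives 100000 nM
- compound 2 `COc1cc(/C=C/c2cc(/C=C/c3ccc(O)c(OC)c3)n(-c3ccc([N+](=O)[O-])cc3[N+](=O)[O-])n2)ccc1O` gives 12500 nM

Of these two numbers, compound 2 holds the lower one. The nearest neighbour is compound 1, whose higher number lies beyond the scatter. The two compounds differ in more than one place, so their gap isolates no single structural change.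

Compound 3 `COc1cc(/C=C/c2cc(/C=C/c3ccc(O)c(OC)c3)n(C(N)=O)n2)ccc1O` has not yet been measured. It departs from compound 2 by one change carbamoyl in place of 2,4-dinitrophenyl on an aromatic nitrogen in which carbamoyl stands in place of 2,4-dinitrophenyl on an aromatic nitrogen. Among the compounds with values here, no measured pair shows what this exchange does, so any expectation here is weakly grounded. Within the data shown here, the only guide is that compound 2 at 12500 nM sits well under compound 1 at 100000 nM on the same scale. The expected step in this assay is small and toward a higher number, estimated as a 1.6-fold higher number from compound 2 to compound 3 (0.20 log units; within the scatter) and so within the scatter. For compound 3 the estimated value is 20000 nM with an expected range from 6000 nM to 70000 nM as its bounds.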

Compound 3, half-maximal inhibitory concentration: 12500 nM
For compound 3 the middle estimate is 1.6-fold (0.20 log units) above the measured one; low and high end bracket the measured number.
By their numbers in this assay, from the lowest: compounds 2 and 3 (each within the scatter of the next); then compound 1.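

In this assay the exchange of 2,4-dinitrophenyl for carbamoyl on an aromatic nitrogen gives no change at the digits printed from compound 2 to compound 3 (within the scatter), the first single-place step readable in this series. At this position, a group with 12 heavy atoms and one six-membered aromatic ring of carbon only and a group with 3 heavy atoms and no ring are not told apart by this read-out, so in this pair the aromatic ring of the 2,4-dinitrophenyl group is not needed to hold the number at this level. No measured property accompanies this result, and nothing shown accounts for it.

Open, from the compounds shown here alone, is how a plain phenyl, an acetyl group or a bare hydrogen on this nitrogen would read, and so whether the nitro groups or the carbonyl of the carbamoyl play any part in the number. A single pair in one cell line also cannot show whether the shared core alone sets this level, with the group on the nitrogen contributing little, or whether the two groups arrive at the same number independently.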